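A few compounds are considered here, and "the series" means these few. Any claim that something is new, unique, unknown or untested is made for them only; others in the source may bear on it.

Measured so far in a functional assay on MCF7 cells (Homo sapiens) for antiproliferative activity, read by MTT assay, with a stated time of 72 h; a higher number here means a weaker inhibitor, a lower number a stronger inhibitor:

Compound 1, `C/C(=N\NC(=O)c1cccc(S(=O)(=O)N2CCOCC2)c1)c1ccc(F)cc1`, gives > 100000 nM, which is a limit of the assay and not a number.
Compound 2, `C/C(=N\NC(=O)c1cccc(S(=O)(=O)N2CCOCC2)c1)c1ccccc1O`, gives 5400 nM.
Compound 3, `C/C(=N\NC(=O)c1cccc(S(=O)(=O)N2CCOCC2)c1)c1ccc(O)cc1`, gives > 100000 nM, again a limit rather than a number.

Compound 3 therefore stands at the limit of > 100000 nM in this assay, at which 2 of the 3 values shown sit, sharing that position with compound 1 and separated from compound 2 by an at least 18-fold higher number from compound 2 to compound 3 (1.26 log units; beyond the scatter). The step from compound 1 to compound 3 is a step that the two limits leave unreadable from compound 1 to compound 3.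

Compound 4, `C/C(=N\NC(=O)c1cccc(S(=O)(=O)N2CCOCC2)c1)c1cc(Br)ccc1O`, is the next to be measured. The change from compound 3 is 5-bromo-2-hydroxyphenyl in place of 4-hydroxyphenyl on a carbon with a double bond to nitrogen. The new group carries the 2-hydroxyphenyl pattern of compound 2, with a bromine added. Among the compounds with values here, the one measured step that bears on this is an at least 18-fold higher number from compound 2 to compound 3 (1.26 log units; beyond the scatter), which runs in the opposite direction to the change made here, so compound 4 is expected to return toward compound 2 with a large fall in the number, estimated as an at least 25-fold lower number from compound 3 to compound 4 (1.39 log units; beyond the scatter). The value of compound 4 in this assay is estimated at 4000 nM, between 800 nM and 20000 nM.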

Compound 4, half-maximal inhibitory concentration: 7830 nM
The estimate for compound 4 lay 2.0-fold (0.29 log units) below the measured number; low and high end bracket the measured number.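

Compound 1 and compound 3 sit at a limit of the assay rather than at a number: the limit of > 100000 nM in this assay, at which 2 of the 4 values shown sit. In this assay, the 5-bromo-2-hydroxyphenyl group brings the series back from that limit, with an at least 12-fold lower number from compound 3 to compound 4 (1.10 log units; beyond the scatter) and an at least 12-fold lower number from compound 1 to compound 4 (1.10 log units; beyond the scatter), so among these four compounds only those carrying the 2-hydroxyphenyl pattern give a measured number. The bromine adds a new point about this position: with a 1.5-fold higher number from compound 2 to compound 4 (0.16 log units; within the scatter), putting bromo in place of hydrogen on an aromatic carbon leaves the result indistinguishable from compound 2.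

From the compounds shown here alone, it remains open whether the hydroxy group itself matters or whether a methoxy group or an amine in its place would serve as well. The compounds shown also cannot tell whether a chlorine or a methyl group would match the bromine.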